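Benzothiazole to benzimidazole on the anilide series

A few compounds are considered here, and "the series" means these few. Any claim that something is new, unique, unknown or untested is made for them only; others in the source may bear on it.

Measured so far:
compound 1 `O=C(Nc1cccc(-c2nc3ccccc3s2)c1)c1cc([N+](=O)[O-])c(O)cc1Cl`: 307 10^-6 cm/s
compound 2 `O=C(Nc1cccc(-c2nc3ccccc3s2)c1)c1cc([N+](=O)[O-])ccc1Cl`: 12 10^-6 cm/s
compound 3 `O=C(Nc1ccc(F)c(-c2nc3ccccc3s2)c1)c1cc([N+](=O)[O-])ccc1Cl`: 17 10^-6 cm/s

In an ADME assay for permeability, using PAMPA, at pH 7.4 (on this read-out higher numbers stand for higher permeability and lower numbers for lower permeability), compound 2 gives the lowest of the three numbers; compound 3 sits nearest, within the scatter, and compound 1 furthest, beyond it. The two steps that have been measured are a 26-fold lower number from compound 1 to compound 2 (1.41 log units; beyond the scatter) and a 1.4-fold higher number from compound 2 to compound 3 (0.15 log units; within the scatter).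

Compound 4 `O=C(Nc1cccc(-c2nc3ccccc3[nH]2)c1)c1cc([N+](=O)[O-])ccc1Cl` has not yet been measured in this assay. Its change from compound 2 is 1H-benzimidazol-2-yl in place of 1,3-benzothiazol-2-yl on an aromatic carbon. Among the compounds with values here, neither measured step touches this part of the molecule: the first concerns the hydroxy on the other ring and the second a fluoro on the central ring, so there is no direct precedent. The entering group carries one hydrogen-bond donor where the leaving group carried none, and in the absence of a matching step the expectation is worded cautiously.

Compound 4 is expected to give 5 10^-6 cm/s, with a range of 1.5 10^-6 cm/s to 15 10^-6 cm/s. This estimate corresponds to a step of a 2.4-fold lower number from compound 2 to compound 4 (0.38 log units; beyond the scatter), expected to be modest but possibly beyond the scatter.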

Compound 4, apparent permeability: 352 10^-6 cm/s
Compound 4: middle estimate off by 70-fold (1.85 log units), on the low side; measured number above the stated range.
By their numbers in this assay, from the lowest: compounds 2 and 3 (each within the scatter of the next); then compounds 1 and 4 (each within the scatter of the next).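

Within the data shown here, the only step at this position is also a large one: in this assay, 1H-benzimidazol-2-yl in place of 1,3-benzothiazol-2-yl gives a 29-fold higher number from compound 2 to compound 4 (1.47 log units; beyond the scatter) on an otherwise unchanged structure. The two groups match in heavy-atom count and ring types, with the entering group differing by nitrogen for sulfur and by carrying a hydrogen-bond donor, so an exchange within the ring system, with no added heavy atoms, is enough for a step of this size. Nothing available identifies which feature of the exchange accounts for the step.

Among these compounds, whether the step persists with the hydroxy or the fluoro of the earlier compounds on the same core remains open. Also open, going by these compounds, is what a methyl group on the ring nitrogen of the 1H-benzimidazol-2-yl would give, which would separate that hydrogen from the rest of the exchange.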